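From butoxy to propylcarbonyl on a shared core

This account rests on a few compounds, and the source may have more. Where it says the series, first, only, none or still open, it means among the compounds named here.

Measured so far in a functional assay on V79 cells (Cricetulus griseus) for cytotoxicity; a higher number here means a weaker inhibitor, a lower number a stronger inhibitor 
- compound 1 `CC(C)CCc1cccc2ccc(=O)oc12` gives 60000 nM 
- compound 2 `CCCCOc1ccc2ccc(=O)oc2c1CCC(C)C` gives 16000 nM 

Compound 2 has the lower number of this pair, which makes it the stronger inhibitor so far. The next compound to be tested is compound 3 `CCCC(=O)c1ccc2ccc(=O)oc2c1CCC(C)C`. It keeps the shared core and the isopentyl group, and it differs from compound 2 at one place, with propylcarbonyl in place of butoxy on an aromatic carbon.

Among the measured compounds shown here, only one measured step bears on this change. That step is a 3.8-fold lower number from compound 1 to compound 2 (0.57 log units; beyond the scatter), and it is modest. It put butoxy in place of hydrogen, so it shows what adding a group did, not what swapping one group for another does. For the measured compounds named here, no measured compound carries propylcarbonyl, so the guidance is indirect. In this assay no step beyond the scatter is expected, in either direction. The expected step is a 1.3-fold higher number from compound 2 to compound 3 (0.10 log units; within the scatter). Compound 3 is estimated at 20000 nM, with an expected range from 7000 nM to 60000 nM.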

Compound 3, half-maximal inhibitory concentration: 58000 nM
The estimate for compound 3 lay 2.9-fold (0.46 log units) below the measured number; the measured number falls inside the stated range.
By their numbers in this assay, from the lowest: compound 2; then compounds 3 and 1 (each within the scatter of the next).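

In this assay, the aromatic carbon ortho to the isopentyl group responds to which group it carries, not only to whether it carries one. Butoxy and propylcarbonyl have the same printed counts of heavy atoms, carbon and oxygen, yet exchanging them gives a 3.6-fold higher number from compound 2 to compound 3 (0.56 log units; beyond the scatter) and so undoes the advantage that compound 2 held over compound 1. Placing propylcarbonyl on the unsubstituted position gives a 1.0-fold lower number from compound 1 to compound 3 (0.01 log units; within the scatter), which shows that the lower number of compound 2 does not follow from simply adding any group with this count of heavy atoms, and nothing available explains why the two groups differ.

Two groups at one position cannot show whether the difference follows the oxygen that joins butoxy to the ring, the carbonyl of propylcarbonyl, or some other feature of these chains. Methoxy, a longer chain such as hexyloxy, or an amine at this position would help to separate these possibilities, and the same swap on a core without the isopentyl group would test whether the pattern holds there.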